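A few compounds are considered here, and "the series" means these few. Any claim that something is new, unique, unknown or untested is made for them only; others in the source may bear on it.

Measured so far:
compound 1 `CNC(=O)c1cc(C(=O)NC2CC2)cn(Cc2cccc3[nH]c(C)nc23)c1=O` — 1.5
compound 2 `CNC(=O)c1cc(C(=O)NC2CC2)cn(Cc2cccc([C@@H](C)O)c2)c1=O` — 2.2
compound 3 `CNC(=O)c1cc(C(=O)NC2CCC2)cn(Cc2ccncc2)c1=O` — 1.7

The three compounds share a core and differ in the group on the saturated chain carbon bound to the aromatic nitrogen. In a physicochemical assay for lipophilicity, at pH 7.4 (on this read-out lower numbers stand for lower lipophilicity and higher numbers for higher lipophilicity), compound 2 gives 2.2, the highest of the three numbers. Compound 3 gives 1.7, a reading that lies beyond the scatter below compound 2, and compound 1 gives 1.5, which is further below compound 2 and also beyond the scatter. Whether these gaps follow from the changed group alone cannot be said, since compound 3 also carries a different amide substituent.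

Compound 4 `CNC(=O)c1cc(C(=O)NC2CC2)cn(Cc2cccc3cc[nH]c23)c1=O` is not yet measured in this assay. It differs from compound 2 in one place: 1H-indol-7-yl in place of 3-(1-hydroxyethyl)phenyl on a saturated chain carbon bound to an aromatic nitrogen. The group that leaves carries one hydrogen-bond acceptor, the group that enters carries none; both keep one hydrogen-bond donor.

Given that compound 1, which carries a related bicyclic group with two hetero atoms, gives 1.5, and that compound 2 gives 2.2, an upward step of modest size from compound 2 to compound 4 is expected, a number 0.40 log units higher from compound 2 to compound 4 (beyond the scatter). For compound 4 the expected value in this assay is 2.6, with a range from 2.2 to 3.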

Compound 4, distribution coefficient: 3.7
For compound 4 the middle estimate is 1.10 log units below the measured one, and the stated range ends below it.
By their numbers in this assay, from the lowest: compounds 1 and 3 (each within the scatter of the next); then compound 2; then compound 4.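

In this assay, 1H-indol-7-yl in place of 3-(1-hydroxyethyl)phenyl on a saturated chain carbon bound to an aromatic nitrogen gives a number 1.50 log units higher from compound 2 to compound 4 (beyond the scatter) with the rest of the structure held fixed, so this one place alone can move the read-out by a large amount. The two groups match in heavy-atom count and in donor count, so these counts do not separate them, and bicyclic groups do not group together here: compound 1 gives 1.5 while compound 4 gives 3.7 with the same two amide groups on the shared core. The data shown offer no explanation for the size of the step.

A plain phenyl or a 1-methylindol-7-yl group on the same carbon would help separate the contribution of the fused ring from that of the indole ring hydrogen. Going by these compounds, whether a step of this size carries over to the amide substituent of compound 3, and how a carboxylic acid or an amine on the phenyl ring of compound 2 would read, remains open.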